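Working notes: cytotoxicity of compounds 1 to 3

A few compounds are considered here, and "the series" means these few. Any claim that something is new, unique, unknown or untested is made for them only; others in the source may bear on it.

Measured so far:
compound 1 `CCc1ccc(-n2nc(-c3ccc(C(F)(F)F)cc3O)nc2-c2ccccc2O)cc1` — 107%
compound 2 `Oc1cc(C(F)(F)F)ccc1-c1nc(-c2ccccc2O)n(-c2ccccc2F)n1` — 100%

In a functional assay on PC-12 cells (Rattus norvegicus) for cytotoxicity, read by MTT assay, with stated times of 2 h and 24 h, tested at 10 uM (on this read-out higher numbers stand for a stronger effect at the one concentration tested and lower numbers for a weaker effect), compound 1 gives 107% and compound 2 gives 100%. Compound 2 holds the lower of the two numbers, with compound 1 nearest; the step of a number 7 percentage points lower from compound 1 to compound 2 (within the scatter) lies within the scatter, so the two compounds are not told apart on this read-out.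

Compound 3 `Oc1cc(C(F)(F)F)ccc1-c1nc(-c2ccccc2O)n(-c2ccc(Cl)cc2Cl)n1` is not yet measured. It differs from compound 2 by 2,4-dichlorophenyl in place of 2-fluorophenyl on an aromatic nitrogen. Within the data shown here, the only measured step at the same aromatic nitrogen is a number 7 percentage points lower from compound 1 to compound 2 (within the scatter), which stayed within the scatter. No measured step involves 2,4-dichlorophenyl, so the numbers give no reason to expect a move in either direction beyond the scatter; the expected step is no change at the digits printed from compound 2 to compound 3 (within the scatter). Compound 3 is therefore estimated at 100%, with a range from 85% to 115%.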

Compound 3, a percentage reported as activity, at one concentration (the size of the read-out at that concentration, not a potency): 95.2%
Compound 3: middle estimate off by 4.8 percentage points, on the high side; the range from low to high includes it.
By their numbers in this assay, from the lowest: compounds 3, 2 and 1 (each within the scatter of the next, the first and the last beyond it).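

In this assay, the change at the aromatic nitrogen now gives a step beyond the scatter, as a number 11.8 percentage points lower from compound 1 to compound 3 (beyond the scatter) shows, and this step is modest. The other new step, a number 4.8 percentage points lower from compound 2 to compound 3 (within the scatter), stays within the scatter, so 2,4-dichlorophenyl and 2-fluorophenyl are not told apart at this position, and compound 2 cannot be separated from either of the other two compounds. Nothing available bears on what lies behind these numbers.

As far as these compounds go, all three compounds carry a substituted phenyl group on this nitrogen, so the effect of an amine or a carboxylic acid on that phenyl group, or of a longer alkyl chain in its place, remains open. Among these compounds, with a single concentration behind each number, it also remains open whether the one step beyond the scatter would hold at other concentrations.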